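Replacing benzoxazole with benzimidazole on a shared core

A few compounds are considered here, and "the series" means these few. Any claim that something is new, unique, unknown or untested is made for them only; others in the source may bear on it.

Three close relatives of one shared core have been tested in an ADME assay on BJ cells (Homo sapiens) for cytotoxicity, with a stated time of 72 h; a lower number here means that less compound is needed, a higher number that more compound is needed for the effect. Compound 3 `O=C(Nc1cccc(-c2nc3ccccc3o2)c1)c1cc([N+](=O)[O-])ccc1Cl` gives > 25000 nM, which is a limit of the assay rather than a number. Compound 1 `O=C(Nc1cc(-c2nc3ccccc3o2)ccc1F)c1cc([N+](=O)[O-])ccc1Cl` gives > 25000 nM, again a limit. Compound 2 `O=C(Nc1cccc(-c2nc3ccccc3s2)c1)c1cc([N+](=O)[O-])ccc1Cl` gives > 27000 nM, also a limit. The two steps that connect them, a step that the two limits leave unreadable from compound 1 to compound 3 and a step that the two limits leave unreadable from compound 2 to compound 3, have no readable size because the limit of > 25000 nM in this assay, at which 2 of the 3 values shown sit, and the limit of > 27000 nM in this assay, at which 1 of the 3 values shown sits, mark both ends of each step.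

Compound 4 `O=C(Nc1cccc(-c2nc3ccccc3[nH]2)c1)c1cc([N+](=O)[O-])ccc1Cl` has not yet been measured. It differs from compound 3 by 1H-benzimidazol-2-yl in place of 1,3-benzoxazol-2-yl on an aromatic carbon. Among the measured compounds shown here, no measured step covers this change, and the two known steps carry no size at all, so no step in either direction beyond the scatter can be expected from them; the only pattern among the three measured compounds is that each sits at a limit, and none goes against it. Compound 4 is therefore expected to give 30000 nM, with a range from 10000 nM to 100000 nM, most likely reported once more as a limit. The step this estimate implies, a step that the limit leaves unreadable from compound 3 to compound 4, is expected to remain unreadable in size.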

Compound 4, half-maximal effective concentration: > 27000 nM
Compound 4: a limit, no number (the forecaster's own chance of this, stated with the estimate: 80%); the middle value lies beyond the limit too.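

Compound 4 gives only a limit of the assay, as do compound 2 and compound 3, so no size can be read for the step from compound 3 to compound 4 or from compound 2 to compound 4. What stays open is whether 1H-benzimidazol-2-yl, 1,3-benzoxazol-2-yl and 1,3-benzothiazol-2-yl on the shared core differ in effect at all, and at what concentration any of these compounds would act.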